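Heptylamino to Octyloxy on a Shared Diphenyl Core

The source may report more compounds than this note shows. Statements on the series, on what has been measured and on what is new or still open speak of the compounds shown alone.

Compound 1 `O=C(O)CCCCCCn1nc(-c2ccccc2)c(-c2ccccc2)cc1=O` and compound 2 `O=C(O)CCCCCCCn1nc(-c2ccccc2)c(-c2ccccc2)cc1=O` carry acid-bearing chains on their shared core. In an assay on microsomes from liver for inhibition of sterol O-acyltransferase 1 (Rattus norvegicus) (a lower number here means a stronger inhibitor, a higher number a weaker inhibitor), compound 1 gives only a limit, > 300000 nM. Compound 2 likewise gives only a limit, > 300000 nM. The step that the two limits leave unreadable from compound 1 to compound 2 is therefore unreadable because of the limit of > 300000 nM in this assay, at which 2 of the 3 values shown sit. Among the compounds with values here, compound 3 `CCCCCCCNc1cc(-c2ccccc2)c(-c2ccccc2)nn1` gives 55000 nM, the only real number among the three values shown. Compound 4 `CCCCCCCCOc1cc(-c2ccccc2)c(-c2ccccc2)nn1` differs from compound 3 by octyloxy in place of heptylamino on an aromatic carbon. Within the data shown here, no measured step touches this kind of change, and the single measured step is unreadable, so for compound 4 a shift no larger than the usual scatter is expected, in no fixed direction. The estimate for compound 4 is 60000 nM, between 20000 nM and 250000 nM, which means an expected step of a 1.1-fold higher number from compound 3 to compound 4 (0.04 log units; within the scatter).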

Compound 4, half-maximal inhibitory concentration: 104000 nM
The estimate for compound 4 lay 1.7-fold (0.24 log units) below the measured number; the range from low to high includes it.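

At this aromatic carbon, octyloxy stands in place of heptylamino with a 1.9-fold higher number from compound 3 to compound 4 (0.28 log units; within the scatter) in this assay. Heptylamino carries a hydrogen-bond donor and octyloxy carries none, yet this single pair shows no step beyond the scatter, so the swap of nitrogen for oxygen together with the added heavy atom leaves the reading unmoved here. Going by these compounds, what a decyloxy chain or a benzyloxy group would give at this carbon stays open. The step between the two acid-bearing compounds also cannot be read: the limit of > 300000 nM in this assay, at which 2 of the 4 values shown sit.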